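Working notes: exchanging the side chain of compound 1

A few compounds are considered here, and "the series" means these few. Any claim that something is new, unique, unknown or untested is made for them only; others in the source may bear on it.

Compound 1 `COC1=CC(=O)c2ncnc(NCCCN(C)C)c2C1=O`: 1730 nM
Compound 2 `CN(C)CCCNc1ncnc2c1C(=O)C(N1CCCCC1)=CC2=O`: 1170 nM

Both values come from a functional assay on L1210 cells (Mus musculus) for inhibition; a lower number here means a stronger inhibitor, a higher number a weaker inhibitor. Compound 1 holds the higher of the two numbers, but it stands level with compound 2 within the scatter, as shown by a 1.5-fold lower number from compound 1 to compound 2 (0.17 log units; within the scatter). That step puts piperidin-1-yl in place of methoxy on a double-bonded ring carbon.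

Compound 3 `COC(=O)CNc1ncnc2c1C(=O)C(OC)=CC2=O` keeps that methoxy and changes the chain instead: methoxycarbonyl in place of 2-(dimethylamino)ethyl on a saturated chain carbon bound to a nitrogen on an aromatic ring. In words, methoxycarbonyl stands in place of 2-(dimethylamino)ethyl on a saturated chain carbon bound to a nitrogen on an aromatic ring, so 3-(dimethylamino)propyl becomes (methoxycarbonyl)methyl.

For the measured compounds named here, no measured step touches this chain. Going by the values given here, the single step available lies elsewhere on the molecule and gives only indirect guidance, so the size of this change remains poorly defined. A moderate estimated step, a 1.7-fold higher number from compound 1 to compound 3 (0.24 log units; within the scatter), is expected in this assay, with low confidence in its direction. Compound 3 is estimated at 3000 nM, with an expected range of 800 nM to 12000 nM.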

Compound 3, half-maximal inhibitory concentration: 4260 nM
Compound 3: the middle estimate sits 1.4-fold (0.15 log units) below what was measured, and the stated range covers the measured number.
By their numbers in this assay, from the lowest: compounds 2 and 1 (each within the scatter of the next); then compound 3.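

In this assay the side chain, with the methoxy held in place, gives a 2.5-fold higher number from compound 1 to compound 3 (0.39 log units; beyond the scatter), a modest step but one beyond the scatter, whereas a 1.5-fold lower number from compound 1 to compound 2 (0.17 log units; within the scatter) stayed within it. Among the steps shown, the saturated chain carbon bound to a nitrogen on an aromatic ring is therefore the first place where a single exchange moves the number measurably, yet the 3-(dimethylamino)propyl chain is not needed for measurable inhibition: compound 3, carrying (methoxycarbonyl)methyl, still reads 4260 nM on the same core. No evidence is available that accounts for the size or direction of this step.

The exchange alters both the chain and the group at its end in one move, so the two contributions cannot be separated with these compounds alone. A longer chain ending in methoxycarbonyl, a short chain ending in a dimethylamino group, or a carboxylic acid in place of the methyl ester would pull these apart, and pairing (methoxycarbonyl)methyl with piperidin-1-yl would test whether the two changes act independently.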